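Dialkylamino Chains on a Flavone Core: Antiproliferative Potency

This account rests on a few compounds, and the source may have more. Where it says the series, first, only, none or still open, it means among the compounds named here.

Measured compounds:
compound 1, `CCCOc1c(-c2cc(OC)c(OC)c(OC)c2)oc2ccccc2c1=O`: 5700 nM
compound 2, `CCCCN(CCCC)CCCCOc1c(-c2cc(OC)c(OC)c(OC)c2)oc2ccccc2c1=O`: 7800 nM

Of the compounds shown here, two sharing one core have been tested in a functional assay on LNCaP cells (Homo sapiens) for antiproliferative activity, read by WST assay, with a stated time of 3 days; a higher number here means a weaker inhibitor, a lower number a stronger inhibitor. Of the two numbers, the figure for compound 1 is the smaller, yet the gap to compound 2 is within the scatter, so the two cannot be told apart on potency. Within the data shown here, the one measured step, a 1.4-fold higher number from compound 1 to compound 2 (0.14 log units; within the scatter), shows that attaching a dibutylamino-bearing arm to the chain barely moves the read-out.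

Compound 3, `CCCCCN(CCCCC)CCCOc1c(-c2cc(OC)c(OC)c(OC)c2)oc2ccccc2c1=O`, is the next case: dipentylamino in place of hydrogen on a saturated chain carbon, three bonds along the chain from an oxygen on an aromatic ring. Among the measured compounds shown here, this change resembles the one from compound 1 to compound 2, adding a longer dialkylamino group to a slightly shorter chain. Since that earlier step stayed within the scatter, a similarly small step is expected in this assay, in no particular direction. The estimate for compound 3 is therefore 7000 nM, within 3000 nM to 16000 nM, and the expected step is a 1.2-fold higher number from compound 1 to compound 3 (0.09 log units; within the scatter).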

Compound 3, half-maximal inhibitory concentration: 5100 nM
Estimate against measurement, compound 3: 1.4-fold (0.14 log units) above, within the range that was stated.
By their numbers in this assay, from the lowest: compounds 3, 1 and 2 (each within the scatter of the next).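

In this assay, placing dipentylamino on a saturated chain carbon, three bonds along the chain from an oxygen on an aromatic ring, gives a 1.1-fold lower number from compound 1 to compound 3 (0.05 log units; within the scatter) and so leaves compound 3 indistinguishable from compound 1, which carries only the plain chain. Exchanging the arm at that same place gives a 1.5-fold lower number from compound 2 to compound 3 (0.18 log units; within the scatter) and so does not separate the dipentylamino compound from the one with (dibutylamino)methyl either. Two different dialkylamino arms have now been seen here, and all three compounds stay within the scatter of one another, so this place accepts a group of 11 heavy atoms with no readable change in antiproliferative potency, and no supporting data on why the number holds steady are available.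

The compounds shown leave open whether a smaller amine such as dimethylamino, or a ring amine such as piperidine or morpholine, would behave the same way at this place. They also leave open whether a carboxylic acid at the end of the chain would produce a step beyond the scatter.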